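The source may hold more compounds than are shown below. What is called first, only, known or untested is meant among the compounds shown, and "the series" means these compounds.

Three compounds have been measured in an ADME assay on MDCK cells (Canis lupus familiaris) for cytotoxicity, read by MTT assay, with a stated time of 24 h; a higher number here means that more compound is tolerated, a lower number that less compound is tolerated:

Compound 1 `Cc1cc(CNS(=O)(=O)c2ccc([N+](=O)[O-])cc2)c(C)o1`: > 152000 nM (a limit)
Compound 2 `Cc1cc(CNS(=O)(=O)c2ccc([N+](=O)[O-])cc2)c(C)s1`: > 204000 nM (a limit)
Compound 3 `Cc1cc(CNS(=O)(=O)c2ccc(C#N)cc2)c(C)s1`: > 217000 nM (a limit)

Compound 2 stands at > 204000 nM, which is a limit and not a number. Among the compounds with values here, the two other compounds also give only limits, so no compound can be ranked against another.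

Compound 4 `O=[N+]([O-])c1ccc(S(=O)(=O)NCc2cccs2)cc1` has thiophen-2-yl in place of 2,5-dimethylthiophen-3-yl on a saturated chain carbon bound to a sulfonamide nitrogen.

The nearest measured change is a step that the two limits leave unreadable from compound 1 to compound 2, which also alters the group at this place. The other is a step that the two limits leave unreadable from compound 2 to compound 3, at a different place. Neither gives a size to carry over, so no step beyond the scatter is expected in this assay, in either direction. The expected outcome is a step that the limit leaves unreadable from compound 2 to compound 4, and compound 4 will probably be reported as a limit too.

The estimated value for compound 4 is 220000 nM, with an expected range from 100000 nM to 400000 nM.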

Compound 4, half-maximal cytotoxic concentration: 133000 nM
Beside the measured number, compound 4's estimate is 1.7-fold (0.22 log units) above it; measured number inside the range.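

In this assay, compound 4 is the first of these compounds to give a number rather than a limit, whereas the steps among compound 1, compound 2 and compound 3 cannot be read. From the compounds shown here alone, with thiophen-2-yl on a saturated chain carbon bound to a sulfonamide nitrogen, the change therefore gains a direction, as an at least 1.5-fold lower number from compound 2 to compound 4 (0.18 log units; that floor lies within the scatter) and an at least 1.1-fold lower number from compound 1 to compound 4 (0.05 log units; that floor lies within the scatter), but each floor lies within the scatter and the true size of each step stays unknown. The first of these floors rests on the reading of compound 2, which is only a limit: the limit of > 204000 nM in this assay, at which 1 of the 4 values shown sits.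

The compounds shown leave open where the number would fall with thiophen-3-yl, phenyl or a longer chain at this place. They also leave open whether cyano in place of nitro would read differently alongside thiophen-2-yl.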